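Sulfonamide nitrogen variation in the shared core series

The source may hold more compounds than are shown below. What is called first, only, known or untested is meant among the compounds shown, and "the series" means these compounds.

Compound 2 `CN(c1cccc2ccccc12)S(=O)(=O)C1CC2OC1C(c1ccc(NC(=O)CCCCCCC(=O)O)cc1)=C2c1ccc(O)cc1` gives 14000 nM in a functional assay on MCF7 cells (Homo sapiens) for antiproliferative activity, read by MTT assay, with a stated time of 72 h (on this read-out higher numbers stand for weaker inhibition and lower numbers for stronger inhibition), the lowest of the three numbers; compound 1 `Cc1cccc(N(C)S(=O)(=O)C2CC3OC2C(c2ccc(NC(=O)CCCCCCC(=O)O)cc2)=C3c2ccc(O)cc2)c1` gives 30200 nM and compound 3 `CCN(c1cccc(OC)c1)S(=O)(=O)C1CC2OC1C(c1ccc(NC(=O)CCCCCCC(=O)O)cc1)=C2c1ccc(O)cc1` gives 37400 nM. Compound 4 `CCN(c1ccccc1Br)S(=O)(=O)C1CC2OC1C(c1ccc(NC(=O)CCCCCCC(=O)O)cc1)=C2c1ccc(O)cc1` carries the change ((2-bromophenyl)(ethyl)amino in place of methyl(naphthalen-1-yl)amino on a sulfonyl sulfur). For the measured compounds named here, two steps bear on it: a 2.2-fold lower number from compound 1 to compound 2 (0.33 log units; beyond the scatter) and a 2.7-fold higher number from compound 2 to compound 3 (0.43 log units; beyond the scatter), both modest and beyond the scatter, and both show that a single aromatic ring in place of naphthalen-1-yl on the sulfonamide nitrogen raises the number. A similar modest rise is therefore expected here, a 2.1-fold higher number from compound 2 to compound 4 (0.33 log units; beyond the scatter). Compound 4 is estimated at 30000 nM in this assay, with a range from 12000 nM to 75000 nM, though the listed compounds 1 and 3 do not separate clearly from each other.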

Compound 4, half-maximal inhibitory concentration: > 100000 nM
Compound 4 ended at the assay's limit; the forecaster's own chance of this, stated with the estimate: 10%; middle value at least 3.3-fold (0.52 log units) from the limit.
By their numbers in this assay, from the lowest: compound 2; then compounds 1 and 3 (each within the scatter of the next). At a limit, above all of these: compound 4.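

Compound 4 sits at a limit, not a number: the limit of > 100000 nM in this assay, at which 1 of the 4 values shown sits. The steps to it are an at least 7.1-fold higher number from compound 2 to compound 4 (0.85 log units; beyond the scatter), an at least 2.6-fold higher number from compound 3 to compound 4 (0.42 log units; beyond the scatter) and an at least 3.3-fold higher number from compound 1 to compound 4 (0.51 log units; beyond the scatter), and each gives only a lower bound. On the sulfonamide nitrogen, then, a single aromatic ring does not set one level: 2-bromophenyl with ethyl separates from the 3-methylphenyl and 3-methoxyphenyl groups of compound 1 and compound 3.

The compounds shown leave open whether the bromine or the ring carrying it accounts for this step. Also open, as far as these compounds go, is whether an aminophenyl group or a chain longer than ethyl on that nitrogen would return the number towards that of compound 2.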